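Trading an aromatic group for a cyclohexene ring

The source may hold more compounds than are shown below. What is called first, only, known or untested is meant among the compounds shown, and "the series" means these compounds.

In a functional assay on MDA-MB-231 cells (Homo sapiens) for antiproliferative activity, read by MTT assay, with a stated time of 48 h (a lower number here means a stronger inhibitor, a higher number a weaker inhibitor), compound 1 `C=CS(=O)(=O)N1CCN(c2ncnc3sc(-c4ccc(OC)cc4)cc23)CC1` gives 29900 nM, compound 2 `C=CS(=O)(=O)N1CCN(c2ncnc3sc(-c4cccc5ncccc45)cc23)CC1` gives 21000 nM and compound 3 `C=CS(=O)(=O)N1CCN(c2ncnc3sc(-c4cc(Br)cnc4F)cc23)CC1` gives 24100 nM, so compound 3 stands level with the other two, within the scatter. Compound 4 `C=CS(=O)(=O)N1CCN(c2ncnc3sc(C4=CCCCC4)cc23)CC1` carries cyclohex-1-en-1-yl in place of 5-bromo-2-fluoropyridin-3-yl on an aromatic carbon. Three measured steps exchange a group at this same place: a 1.4-fold lower number from compound 1 to compound 2 (0.15 log units; within the scatter), a 1.2-fold lower number from compound 1 to compound 3 (0.09 log units; within the scatter) and a 1.1-fold higher number from compound 2 to compound 3 (0.06 log units; within the scatter). Each lies within the scatter, although every group tried so far is aromatic and the new one is not. No change beyond the scatter is therefore expected in this assay. The expected step is a 1.0-fold lower number from compound 3 to compound 4 (0.00 log units; within the scatter). Compound 4 is estimated at 24000 nM, with a range of 10000 nM to 50000 nM.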

Compound 4, half-maximal inhibitory concentration: > 50000 nM
Compound 4 ended at the assay's limit; the forecaster's own chance of this, stated with the estimate: 10%; middle value at least 2.0-fold (0.31 log units) away from the limit.
By their numbers in this assay, from the lowest: compounds 2, 3 and 1 (each within the scatter of the next). At a limit, above all of these: compound 4.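

Compound 4 gives only a limit in this assay, not a number: the limit of > 50000 nM in this assay, at which 1 of the 4 values shown sits. The position is therefore not indifferent to every group, as cyclohex-1-en-1-yl, the only non-aromatic ring among those shown, brings an at least 2.0-fold higher number from compound 3 to compound 4 (0.31 log units; beyond the scatter) and an at least 2.3-fold higher number from compound 2 to compound 4 (0.37 log units; beyond the scatter). The remaining step is an at least 1.6-fold higher number from compound 1 to compound 4 (0.22 log units; that floor lies within the scatter) and cannot be read.

The compounds shown leave open whether the loss of the aromatic ring or some other difference between these groups accounts for the change. On these data alone, it also remains open whether a saturated cyclohexyl ring or a piperidine at this place would behave like cyclohex-1-en-1-yl or like the aromatic groups.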